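A Lone Measured Value Ahead of an Amino Swap

This account rests on a few compounds, and the source may have more. Where it says the series, first, only, none or still open, it means among the compounds named here.

Going by the values given here, in a functional assay on RPMI18226 cells (Homo sapiens) for cytotoxicity, read by fluorescence and resazurin assay, with a stated time of 72 h (a lower number here means a stronger inhibitor, a higher number a weaker inhibitor), compound 2 `Nc1nc(Nc2ccc(S(N)(=O)=O)cc2)sc1C(=O)c1cccc(F)c1` gives 6800 nM as the only actual number so far. Compound 1 `Nc1nc(Nc2ccc(S(N)(=O)=O)cc2)sc1C(=O)c1ccccc1[N+](=O)[O-]` shows > 10000 nM as a limit of the assay. Compound 3 `Nc1nc(Nc2ccc(S(N)(=O)=O)cc2)sc1C(=O)c1ccc(S(N)(=O)=O)cc1` shows > 10000 nM as a limit too. Compound 4 `Nc1cccc(C(=O)c2sc(Nc3ccc(S(N)(=O)=O)cc3)nc2N)c1` has amino in place of fluoro on an aromatic carbon, meta to a large group, counted as amino in place of fluoro on an aromatic carbon here. Among the compounds with values here, only one measured step exists, an at least 1.4-fold lower number from compound 1 to compound 2 (0.16 log units; that floor lies within the scatter), and it changes another group, so it gives little guidance. No step beyond the scatter is therefore expected in this assay for this swap. The estimated step is a 1.0-fold higher number from compound 2 to compound 4 (0.01 log units; within the scatter), with a real chance of a limit instead. Compound 4 is expected near 7000 nM, with an estimated range from 2500 nM to 10000 nM.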

Compound 4, half-maximal inhibitory concentration: > 10000 nM
Compound 4 gave a limit, no number (the forecaster's own chance of this, stated with the estimate: 40%); middle value at least 1.4-fold (0.15 log units) from the limit.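

In this assay, going by these compounds, amino in place of fluoro on an aromatic carbon gives an at least 1.4-fold higher number from compound 2 to compound 4 (0.16 log units; that floor lies within the scatter), so this swap shows no gain, though the true size of the step remains unknown. The step from compound 1 to compound 4 cannot be read, as both values are limits. Compound 4 now joins the group that gives no number, leaving compound 2 as the only compound with one: the limit of > 10000 nM in this assay, at which 3 of the 4 values shown sit.

On these data alone, how far compound 4 lies past its limit stays open. So does whether a methoxy group or a chlorine atom on this aromatic carbon would give a lower number than compound 2.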